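Compound 2 to compound 3: swapping the chain end

The source may report more compounds than this note shows. Statements on the series, on what has been measured and on what is new or still open speak of the compounds shown alone.

Values in a physicochemical assay for lipophilicity, at pH 7.4; on this read-out higher numbers stand for higher lipophilicity and lower numbers for lower lipophilicity
- Compound 1 `CS(=O)(=O)Cc1cccc2c1CCC2c1ncc[nH]1` gives 0.7
- Compound 2 `COCCc1cccc2c1CCC2c1ncc[nH]1` gives 2
- Compound 3 `Fc1ccn(Cc2cccc3c2CCC3c2ncc[nH]2)n1` has not yet been measured

Compound 2 holds the higher of the two numbers, at 2. The change under consideration is 3-fluoro-1H-pyrazol-1-yl in place of methoxymethyl on a saturated chain carbon bound to an aromatic carbon, with 3-fluoro-1H-pyrazol-1-yl in place of methoxymethyl on a saturated chain carbon bound to an aromatic carbon.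

Among the measured compounds shown here, one measured step bears on this place: a number 1.30 log units higher from compound 1 to compound 2 (beyond the scatter). That step is large and beyond the scatter, so this assay can move strongly with a change here. Its size does not carry over directly, however. For the measured compounds named here, the step replaces methylsulfonyl, and no measured compound carries 3-fluoro-1H-pyrazol-1-yl. Methoxymethyl is the only group it shares with the present change.

With so little to go on, a small upward move is expected, not clearly beyond the scatter. The expected step is a number 0.30 log units higher from compound 2 to compound 3 (within the scatter). Compound 3 is estimated at 2.3, with an expected range of 1.7 to 2.9.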

Compound 3, distribution coefficient: 2.4
Beside the measured number, compound 3's estimate is 0.10 log units below it, within the range that was stated.
By their numbers in this assay, from the lowest: compound 1; then compound 2; then compound 3.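

In this assay, an aromatic ring at this place, on a saturated chain carbon bound to an aromatic carbon, gives a further rise: 3-fluoro-1H-pyrazol-1-yl in place of methoxymethyl gives a number 0.40 log units higher from compound 2 to compound 3 (beyond the scatter), so the read-out here can still move beyond the scatter when the group replaced is not methylsulfonyl. Against methylsulfonyl, the same group gives a number 1.70 log units higher from compound 1 to compound 3 (beyond the scatter), and the three groups now fall in one order at this place, with methylsulfonyl lowest, methoxymethyl next and 3-fluoro-1H-pyrazol-1-yl highest, with no compound among the three going against that order. No measurement at hand accounts for these differences.

How much of the rise belongs to the ring and how much to its fluorine stays open: the compounds shown include no plain 1H-pyrazol-1-yl at this place to separate the two. Also open, from the compounds shown here alone, is how a dimethylamino group, a carboxylic acid or a longer chain at the same place would read in this assay, and whether the order of the three groups holds on any other core.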